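A few compounds are considered here, and "the series" means these few. Any claim that something is new, unique, unknown or untested is made for them only; others in the source may bear on it.

Measured so far:
compound 1, `Cc1cn(C2CC(N=[N+]=[N-])C(COC(=O)NCCCO)O2)c(=O)[nH]c1=O`: in an ADME assay on the whole organism (serum) with Homo sapiens as the target (a higher number here means that the compound lasts longer, a lower number that the compound disappears faster), compound 1 gives > 48 h, which is a limit of the assay and not a number.
compound 2, `Cc1cn(C2CC(N=[N+]=[N-])C(COC(=O)NCCCC(=O)O)O2)c(=O)[nH]c1=O`: in this assay compound 2 gives > 48 h, again a limit rather than a number.
compound 3, `Cc1cn(C2CC(N=[N+]=[N-])C(COC(=O)OCCCO)O2)c(=O)[nH]c1=O`: in this assay compound 3 gives 0.167 h.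

From compound 1 to compound 2 the change is carboxy in place of hydroxy on a saturated chain carbon, three bonds along the chain from an amide-type nitrogen. Its step, a step that the two limits leave unreadable from compound 1 to compound 2, cannot be read because both values sit at the limit of > 48 h in this assay, at which 2 of the 3 values shown sit. Compound 4, `Cc1cn(C2CC(N=[N+]=[N-])C(COC(=O)OCCCC(=O)O)O2)c(=O)[nH]c1=O`, is not yet measured and differs from compound 3 by carboxy in place of hydroxy on a saturated chain carbon, three bonds along the chain from an oxygen next to a carbonyl group. This is the same kind of change, but the place is not identical: in the first pair the chain runs from an amide-type nitrogen, in the second from an oxygen next to a carbonyl group. The two cores themselves differ by 3-hydroxypropoxy in place of (3-hydroxypropyl)amino on a carbonyl carbon, a step of an at least 280-fold lower number from compound 1 to compound 3 (2.45 log units; beyond the scatter).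

For compound 4 in this assay the step of a 1.2-fold higher number from compound 3 to compound 4 (0.08 log units; within the scatter) is expected to be small. That expectation rests on compound 3 and its value 0.167 h, and on the earlier step, which was unreadable and so gives no reason to expect a large shift. Compound 4 is estimated at 0.2 h, with a likely range from 0.05 h to 1 h.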

Compound 4, half-life in the Homo sapiens assay: 13 h
For compound 4 the middle estimate is 65-fold (1.81 log units) below the measured one, outside the stated range (above it).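

In the Homo sapiens assay, compound 3 gives 0.167 h and compound 4 gives 13 h, and carboxy in place of hydroxy on the core of compound 3 gives a 78-fold higher number from compound 3 to compound 4 (1.89 log units; beyond the scatter). On the core of compound 1 the same kind of change cannot be read, since compound 1 and compound 2 both give a limit and not a number: the limit of > 48 h in the Homo sapiens assay, at which 2 of the 4 values shown sit. The change is therefore shown on one core only, and whether it carries over stays unknown; the two cores still differ, as 3-carboxypropoxy in place of (3-carboxypropyl)amino gives an at least 3.6-fold lower number from compound 2 to compound 4 (0.56 log units; beyond the scatter) and 3-carboxypropoxy in place of (3-hydroxypropyl)amino gives an at least 3.6-fold lower number from compound 1 to compound 4 (0.56 log units; beyond the scatter). In a physicochemical assay for lipophilicity (on this read-out higher numbers stand for higher lipophilicity and lower numbers for lower lipophilicity), compound 3 gives -0.98 and compound 4 gives -0.55.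

The compounds shown leave open whether an amine in place of the carboxy group would act in the same way on either core. Going by these compounds, a longer chain carrying the carboxy group is equally open.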